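Replacing a fluorinated biaryl arm with an isopropoxy-bearing ring

The compounds below may be only part of what the source reports. "The series", "measured", "known", "first", "only" and "open" are said of these compounds alone.

Compound 1 `C[C@@H](C(=O)N[C@H](C#N)CC(N)=O)N(Cc1ccc(-c2ccc(F)c(F)c2)cc1)S(C)(=O)=O` carries two fluoro groups on its outer aromatic ring, and in an assay on isolated protein for inhibition of legumain (Homo sapiens), with stated times of 2 min and 60 min (on this read-out lower numbers stand for stronger inhibition and higher numbers for weaker inhibition), compound 1 gives 252 nM. For the measured compounds named here, compound 2 `C[C@@H](C(=O)N[C@H](C#N)CC(N)=O)N(Cc1ccc(-c2ccc(F)cc2)cc1)S(C)(=O)=O` keeps only one fluoro group on that ring; in this assay compound 2 gives 1040 nM. The move from one to the other, a hydrogen in place of fluoro on an aromatic carbon, brought a 4.1-fold higher number from compound 1 to compound 2 (0.62 log units; beyond the scatter). Among the two compounds measured, compound 2 therefore stands at the highest number, with compound 1 as its only neighbour.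

Compound 3 `CC(C)Oc1cccc(-c2ccc(CN([C@@H](C)C(=O)N[C@H](C#N)CC(N)=O)S(C)(=O)=O)cc2)c1` differs from compound 2 in 3-isopropoxyphenyl in place of 4-fluorophenyl on an aromatic carbon. Going by the values given here, the single measured step, a 4.1-fold higher number from compound 1 to compound 2 (0.62 log units; beyond the scatter), concerns the removal of a fluoro group and not the introduction of a 3-isopropoxyphenyl ring, so it bears on this change only loosely. Among the compounds with values here, no measured pair shows what a 3-isopropoxyphenyl group does in this assay. Compound 3 is therefore expected to show no step beyond the scatter in this assay, the estimated step being a 1.3-fold lower number from compound 2 to compound 3 (0.11 log units; within the scatter), though the uncertainty is wide. For compound 3 the estimate in this assay is 800 nM, ranging from 200 nM to 3200 nM.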

Compound 3, half-maximal inhibitory concentration: 882 nM
Beside the measured number, compound 3's estimate is 1.1-fold (0.04 log units) below it; the range from low to high includes it.
By their numbers in this assay, from the lowest: compound 1; then compounds 3 and 2 (each within the scatter of the next).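

In this assay, exchanging the outer ring of compound 2 gives a 1.2-fold lower number from compound 2 to compound 3 (0.07 log units; within the scatter) even though the entering 3-isopropoxyphenyl group has 10 heavy atoms against 7 and brings a hydrogen-bond acceptor, so on this aromatic carbon neither the larger group nor the acceptor moves the read-out beyond the scatter. Measured against the 3,4-difluorophenyl ring, the same group gives a 3.5-fold higher number from compound 1 to compound 3 (0.54 log units; beyond the scatter) and thus sets compound 3 apart from compound 1, leaving compound 1 as the only one of the three whose number stands clear of the others. The data shown offer no measurement that accounts for either step.

Going by these compounds, it remains open whether the oxygen or the branched chain of the 3-isopropoxyphenyl group counts for more, a question that a 3-methoxyphenyl or a 3-isopropylphenyl ring in the same place would address. Also open, on these data alone, is whether a fluoro group added to the 3-isopropoxyphenyl ring would bring the number towards that of compound 1, or whether an amine or a carboxylic acid on this outer ring would shift it in either direction.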